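Trading trifluoromethyl for cyano on compound 2

This account rests on a few compounds, and the source may have more. Where it says the series, first, only, none or still open, it means among the compounds named here.

In a functional assay on QGY-7703 cells (Homo sapiens) for cytotoxicity, read by MTT assay, with a stated time of 24 h (on this read-out higher numbers stand for weaker inhibition and lower numbers for stronger inhibition), compound 1 `CN1C/C(=C\c2ccc(C#N)cc2)C(=O)/C(=C/c2cccnc2)C1` gives > 20000 nM as a limit of the assay and not as a number. For the measured compounds named here, compound 2 `CN1C/C(=C\c2ccncc2)C(=O)/C(=C/c2ccc(C(F)(F)F)cc2)C1` gives 10400 nM as the only true number so far. Compound 3 `CN1C/C(=C\c2ccncc2)C(=O)/C(=C/c2ccc(C#N)cc2)C1` has cyano in place of trifluoromethyl on an aromatic carbon and has not yet been measured. Going by the values given here, no measured step is available as a guide, so the expected 1.3-fold higher number from compound 2 to compound 3 (0.10 log units; within the scatter) is one that stays within the usual scatter of this assay and points in neither direction. For compound 3 the estimated value is 13000 nM with an expected range from 5500 nM to 30000 nM on this read-out.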

Compound 3, half-maximal inhibitory concentration: 7400 nM
The estimate for compound 3 lay 1.8-fold (0.24 log units) above the measured number, within the range that was stated.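

In this assay, for the compounds shown here, the first measured change at this aromatic carbon gives a 1.4-fold lower number from compound 2 to compound 3 (0.15 log units; within the scatter), so cyano and trifluoromethyl are not told apart here. The change of ring attachment does register, with pyridin-4-yl in place of pyridin-3-yl: an at least 2.7-fold lower number from compound 1 to compound 3 (0.43 log units; beyond the scatter). Compound 1 stands at a limit of the assay and not at a number: the limit of > 20000 nM in this assay, at which 1 of the 3 values shown sits.

As far as these compounds go, whether an amine or a carboxylic acid on this aromatic carbon would move the number beyond the scatter stays open. So does the full size of the step between the two pyridinyl attachments.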